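The source may report more compounds than this note shows. Statements on the series, on what has been measured and on what is new or still open speak of the compounds shown alone.

Measured so far in an ADME assay on microsomes from liver (Homo sapiens) for metabolic stability; a lower number here means slower removal, a higher number faster removal of the compound:
- compound 1, `CN1C(=O)C2=C(C1=O)N(CC(=O)Nc1ccc(-c3ccncc3)cc1)CCC2`: 31 mL.min-1.g-1
- compound 2, `CN1C(=O)C2=C(C1=O)N(CC(=O)Nc1ccc(-c3ccccc3)nc1)CCC2`: 7 mL.min-1.g-1
- compound 3, `Cc1ccc(-c2ccc(NC(=O)CN3CCCC4=C3C(=O)N(C)C4=O)nn2)cn1`: 8 mL.min-1.g-1

Compound 1 stands highest of the three numbers in this assay; compound 3 and compound 2 both sit lower, and both gaps to compound 1 lie beyond the scatter. Among the measured compounds shown here, compounds 2 and 3 carry a different aromatic ring on the amide nitrogen than compound 1, so no single-point step among the measured compounds is available.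

Compound 4, `CN1C(=O)C2=C(C1=O)N(CC(=O)Nc1ccc(-c3nccs3)cc1)CCC2`, differs from compound 1 only in the ring on the aromatic carbon: 1,3-thiazol-2-yl in place of pyridin-4-yl on an aromatic carbon. For the measured compounds named here, with no step of this kind measured, the expected step of a 1.1-fold higher number from compound 1 to compound 4 (0.05 log units; within the scatter) is small, not clearly beyond the scatter, in either direction. Compound 4 is estimated at 35 mL.min-1.g-1 in this assay, within 15 mL.min-1.g-1 to 80 mL.min-1.g-1.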

Compound 4, intrinsic clearance in microsomes: 24 mL.min-1.g-1
The estimate for compound 4 lay 1.5-fold (0.16 log units) above the measured number; the range from low to high includes it.
By their numbers in this assay, from the lowest: compounds 2 and 3 (each within the scatter of the next); then compounds 4 and 1 (each within the scatter of the next).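

In this assay, among the compounds shown here, the first single-place step, at the aromatic carbon para to a large group, is small: 1,3-thiazol-2-yl in place of pyridin-4-yl gives a 1.3-fold lower number from compound 1 to compound 4 (0.11 log units; within the scatter). On this core, a five-membered aromatic ring with two hetero atoms therefore reads the same as a six-membered aromatic ring with one, within the scatter. Nothing at hand explains this result.

Still open, from the compounds shown here alone, is whether a non-aromatic group at this place, such as a piperazine or a carboxylic acid, would give a step beyond the scatter. A single exchange also cannot show whether other aromatic rings here would read alike.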